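Isoindolinone in place of the chlorobenzoic acid group

The compounds below may be only part of what the source reports. "The series", "measured", "known", "first", "only" and "open" are said of these compounds alone.

Measured so far:
compound 1 `Cc1c(OC[C@@H](C)COc2ccc(C(=O)O)c(F)c2)ccc(C(=O)CC(C)(C)C)c1O`, 261 nM
compound 2 `Cc1c(OC[C@@H](C)COc2ccc(C(=O)O)c(Cl)c2)ccc(C(=O)CC(C)(C)C)c1O`, 50 nM

Two compounds share the core and differ only on the aromatic ring at the far end. In an assay for positive allosteric modulation of metabotropic glutamate receptor 2 (Rattus norvegicus) (a lower number here means that less compound is needed, a higher number that more compound is needed for the effect), compound 1 gives 261 nM, and compound 2 gives 50 nM. Among the compounds with values here, the single step, a 5.2-fold lower number from compound 1 to compound 2 (0.72 log units; beyond the scatter), leaves compound 2 with the lower of the two numbers. Compound 3 `Cc1c(OC[C@@H](C)COc2ccc3c(c2)C(=O)NC3)ccc(C(=O)CC(C)(C)C)c1O` carries a different terminal group altogether: a group of 10 heavy atoms (8 carbon, 1 nitrogen, 1 oxygen; one five-membered non-aromatic ring with 1 hetero atom, one six-membered aromatic ring of carbon only) in place of a group of 10 heavy atoms (7 carbon, 2 oxygen, 1 chlorine; one six-membered aromatic ring of carbon only), on an oxygen on a saturated carbon. Within the data shown here, no measured step touches this exchange; the only step seen concerns a halogen on the very group that now leaves, so it says nothing about what the new group will do. With the acid and the chlorine both gone, the outcome is open, and compound 3 is expected to move in this assay by an 8.0-fold higher number from compound 2 to compound 3 (0.90 log units; beyond the scatter), towards a higher number. Compound 3 is estimated at 400 nM, with a range from 60 nM to 3000 nM.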

Compound 3, half-maximal effective concentration: > 10000 nM
Compound 3 gave a limit, no number; the forecaster's own chance of this, stated with the estimate: 15%; at least 25-fold (1.39 log units) between middle value and limit.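

In this assay, compound 3 gave no number, only a limit: the limit of > 10000 nM in this assay, at which 1 of the 3 values shown sits.

The exchange of the 4-carboxy-3-chlorophenyl group for the isoindolinone gives an at least 200-fold higher number from compound 2 to compound 3 (2.30 log units; beyond the scatter), and the exchange of the fluoro counterpart gives an at least 38-fold higher number from compound 1 to compound 3 (1.58 log units; beyond the scatter); the earlier halogen exchange at this end had shown only a 5.2-fold lower number from compound 1 to compound 2 (0.72 log units; beyond the scatter). The terminal group on this oxygen therefore matters far more than the halogen step alone could show, even though the leaving and entering groups match in their counts of heavy atoms, hydrogen-bond donors and hydrogen-bond acceptors.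

The carboxylic acid and the chlorine leave together in this exchange, so the compounds shown do not tell which loss, or the new ring itself, accounts for the step. From the compounds shown here alone, a phenyl group carrying only the carboxylic acid, or a chlorine on the isoindolinone, remains open.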